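Swapping an alkyl branch for a fluorinated benzyl group

A few compounds are considered here, and "the series" means these few. Any claim that something is new, unique, unknown or untested is made for them only; others in the source may bear on it.

Compounds measured so far:
compound 1 `COc1ccc(Oc2ccc3c(NCCCNCc4cccc(OC)c4O)ccnc3c2)cc1` gives 14500 nM
compound 2 `CCC(CC)c1ccc2c(NCCCNCc3cccc(OC)c3O)ccnc2c1` gives 4200 nM
compound 3 `Cc1cc(C)cc(Cc2ccc3c(NCCCNCc4ccco4)ccnc3c2)c1` gives 4200 nM

In a physicochemical assay for solubility, with a stated time of 18 h, at pH 7.4 (on this read-out higher numbers stand for higher solubility and lower numbers for lower solubility), compound 2 stands level with compound 3 at the digits shown, and the two together hold the lowest numbers of the three. Compound 1 sits furthest away, with a 3.5-fold lower number from compound 1 to compound 2 (0.54 log units; beyond the scatter) on the way from it to compound 2.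

Compound 4 `COc1cccc(CNCCCNc2ccnc3cc(Cc4ccc(F)cc4)ccc23)c1O` is not yet measured. It differs from compound 2 in one place: 4-fluorobenzyl in place of pentan-3-yl on an aromatic carbon.

Going by the values given here, only one measured step touches this position of the shared core: a 3.5-fold lower number from compound 1 to compound 2 (0.54 log units; beyond the scatter), in which a ring-bearing group gave way to pentan-3-yl and the number fell. Compound 4 reverses the direction of that change, bringing a ring back, but compound 3 already carries a ring-bearing group on the same core and its value does not differ from that of compound 2 beyond the scatter. With these two observations pulling against each other, the expected step of a 1.2-fold higher number from compound 2 to compound 4 (0.08 log units; within the scatter) is small, at most a slight rise in this assay.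

Compound 4 is therefore expected to give about 5000 nM, with a range from 2000 nM to 12000 nM.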

Compound 4, solubility: 4200 nM
Beside the measured number, compound 4's estimate is 1.2-fold (0.08 log units) above it; the measured number falls inside the stated range.
By their numbers in this assay, from the lowest: compounds 2, 3 and 4 (each within the scatter of the next); then compound 1.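

In this assay, the earlier step from compound 1 to compound 2 removed a ring and the 4-methoxyphenoxy group together, so it could not show which of the two changes went with the lower number. Putting a six-membered aromatic ring of carbon only back at this aromatic carbon, as 4-fluorobenzyl, gives no change at the digits printed from compound 2 to compound 4 (within the scatter), and the comparison with the original group gives a 3.5-fold lower number from compound 1 to compound 4 (0.54 log units; beyond the scatter), so among these three compounds, having a ring in this group does not by itself go with the higher number, and only the compound with 4-methoxyphenoxy stands apart. No measurement at hand explains why these groups give these numbers.

The compounds shown leave open whether the higher number of compound 1 goes with the oxygen joining its ring to the core or with the methoxy group on that ring, a question that a plain phenoxy group at this carbon could help to separate. They also leave open how an amine or a carboxylic acid at this same aromatic carbon would read in this assay.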